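This account rests on a few compounds, and the source may have more. Where it says the series, first, only, none or still open, it means among the compounds named here.

Measured compounds:
compound 1, `Cc1ccc(S(=O)(=O)Oc2ccccc2/C=C(\C#N)C(=O)Nc2nnc(Cc3ccc(Cl)cc3)s2)cc1`, gives 15% in a functional assay on HL-60 cells (Homo sapiens) for inhibition, read by CCK-8 assay, with a stated time of 48 h, tested at 20 uM; a lower number here means less inhibition of growth, a higher number more inhibition of growth at the concentration tested;
compound 2, `COc1ccc(S(=O)(=O)Oc2ccccc2/C=C(\C#N)C(=O)Nc2nnc(Cc3ccc(Cl)cc3)s2)cc1`, gives 99%;
compound 3, `Cc1ccc(Cc2nnc(NC(=O)/C(C#N)=C/c3ccccc3OS(=O)(=O)c3ccc(C)cc3)s2)cc1`, gives 17%.

Compound 1 and compound 2 share one core and differ only in a single spot: methoxy in place of methyl on an aromatic carbon. Within the data shown here, that one change made the step of a number 84 percentage points higher from compound 1 to compound 2 (beyond the scatter), the only large step among the three measured compounds.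

Compound 3 carries a different core than compound 1; the two cores differ by methyl in place of chloro on an aromatic carbon. In this assay that change gave a number 2 percentage points higher from compound 1 to compound 3 (within the scatter), so compound 1 and compound 3 sit within the usual scatter of each other, and no order between them can be claimed.

Compound 4, `COc1ccc(S(=O)(=O)Oc2ccccc2/C=C(\C#N)C(=O)Nc2nnc(Cc3ccc(C)cc3)s2)cc1`, has not yet been measured. It stands to compound 3 as compound 2 stands to compound 1: methoxy in place of methyl on an aromatic carbon. The place of the change is described in the same words for both pairs, so this is the same change made on the second core.

Among the measured compounds shown here, the only guide is the single measured example of this change, from compound 1 to compound 2. On that basis the step from compound 3 to compound 4 is expected to be large, in the same direction as a number 84 percentage points higher from compound 1 to compound 2 (beyond the scatter), giving an estimated a number 71 percentage points higher from compound 3 to compound 4 (beyond the scatter). One example is a thin basis, so the range is kept wide. For compound 4 the estimated value in this assay is 88%, expected to lie between 55% and 100%.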

Compound 4, percent growth inhibition at one concentration: 100%
Estimate against measurement, compound 4: 12 percentage points below; the measured number falls inside the stated range.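

In this assay, putting methoxy in place of methyl on the second core gave a number 83 percentage points higher from compound 3 to compound 4 (beyond the scatter), and this matches what the same change did on the first core: the same change on two cores in this assay, a number 84 percentage points higher (beyond the scatter) from compound 1 to compound 2 and a number 83 percentage points higher (beyond the scatter) from compound 3 to compound 4, 1 percentage points apart, within the scatter of two such steps. Changing the other spot, methyl in place of chloro, gave a number 1 percentage points higher from compound 2 to compound 4 (within the scatter), so that change made no readable difference with either the methyl or the methoxy group on the sulfonyl ring: the same change on two cores in this assay, a number 2 percentage points higher (within the scatter) from compound 1 to compound 3 and a number 1 percentage points higher (within the scatter) from compound 2 to compound 4, 1 percentage points apart, within the scatter of two such steps. Together these results show that, in this small set, the swap from 4-methylphenyl to 4-methoxyphenyl carries over cleanly between two closely related cores, but they do not show why it works, whether it would hold on a more different core, or whether it would hold in other cells or at other concentrations.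

The compounds shown leave open whether this large step belongs to methoxy alone or would also come with ethoxy, a hydroxyl or an amine at the same place, para to a large group. They also leave open how compound 2 and compound 4 would compare at lower concentrations, since a single tested concentration cannot separate them.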